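Morpholin-4-yl for butyl, made a second time

The compounds below may be only part of what the source reports. "The series", "measured", "known", "first", "only" and "open" are said of these compounds alone.

Compound 2 `CCCCC(=O)NC(=S)Nc1nc2cc(Br)ccc2s1` and compound 1 `O=C(NC(=S)Nc1nc2cc(Br)ccc2s1)N1CCOCC1` share one core and differ in a single place: morpholin-4-yl in place of butyl on a carbonyl carbon. In a functional assay on MCF7 cells (Homo sapiens) for cytotoxicity, read by MTT assay, with a stated time of 24 h (a lower number here means a stronger inhibitor, a higher number a weaker inhibitor), compound 2 gives 45700 nM, and compound 1 gives 18100 nM, a step of a 2.5-fold lower number from compound 2 to compound 1 (0.40 log units; beyond the scatter). Compound 3 `CCCCC(=O)NC(=S)Nc1nc2cc(N)ccc2s1` differs from compound 2 in the core itself, where (amino in place of bromo on an aromatic carbon); in this assay compound 3 gives 44700 nM, and the step of a 1.0-fold lower number from compound 2 to compound 3 (0.01 log units; within the scatter) lies within the scatter. Compound 4 `Nc1ccc2sc(NC(=S)NC(=O)N3CCOCC3)nc2c1` stands to compound 3 as compound 1 stands to compound 2: morpholin-4-yl in place of butyl on a carbonyl carbon. The surroundings of the place are the same word for word, so this is the same change, now on the core carrying amino. Because the earlier step of a 2.5-fold lower number from compound 2 to compound 1 (0.40 log units; beyond the scatter) was beyond the scatter, compound 4 is expected to show a step of a 2.5-fold lower number from compound 3 to compound 4 (0.40 log units; beyond the scatter) in this assay. For compound 4 the estimated value in this assay is 18000 nM, likely between 8000 nM and 40000 nM.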

Compound 4, half-maximal inhibitory concentration: 26400 nM
Compound 4: middle estimate off by 1.5-fold (0.17 log units), on the low side; the range from low to high includes it.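

In this assay, morpholin-4-yl in place of butyl on a carbonyl carbon gives steps on the two cores that cannot be told apart: the same change on two cores in this assay, a 2.5-fold lower number (0.40 log units; beyond the scatter) from compound 2 to compound 1 and a 1.7-fold lower number (0.23 log units; within the scatter) from compound 3 to compound 4, 1.5-fold (0.17 log units) apart, within the scatter of two such steps. Amino in place of bromo on an aromatic carbon likewise gives steps that cannot be told apart with either group on the carbonyl carbon: the same change on two cores in this assay, a 1.0-fold lower number (0.01 log units; within the scatter) from compound 2 to compound 3 and a 1.5-fold higher number (0.16 log units; within the scatter) from compound 1 to compound 4, 1.5-fold (0.17 log units) apart, within the scatter of two such steps. Taken alone, however, neither a 1.7-fold lower number from compound 3 to compound 4 (0.23 log units; within the scatter) nor a 1.5-fold higher number from compound 1 to compound 4 (0.16 log units; within the scatter) shows a real change in the number, and two cores in one assay set no rule for the series.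

From the compounds shown here alone, it remains open whether morpholin-4-yl gives a similar step on cores carrying a carboxylic acid or a nitrile in place of bromo or amino. Going by these compounds, it is also open how a piperazine or a longer chain on the carbonyl carbon would compare.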